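The source may report more compounds than this note shows. Statements on the series, on what has been measured and on what is new or still open speak of the compounds shown alone.

Measured in an ADME assay on Caco-2 cells (Homo sapiens) for permeability, in the apical to basolateral direction; a lower number here means that the compound crosses the layer more slowly, a higher number that the compound crosses the layer faster:
- Compound 1 `C[C@H]1C[C@@H](c2ccncc2NC(=O)c2nc(-c3ncccc3F)ccc2N)C[C@@H](O)[C@@]1(O)CF`: 14.6 10^-6 cm/s
- Compound 2 `CC[C@]1(O)[C@H](O)C[C@H](c2ccncc2NC(=O)c2nc(-c3ncccc3F)ccc2N)C[C@@H]1C`: 30.3 10^-6 cm/s

Compound 2 has the higher of the two numbers in this assay, at 30.3 10^-6 cm/s. Going by the values given here, its only measured neighbour is compound 1, and the one measured step is modest and beyond the scatter: a 2.1-fold higher number from compound 1 to compound 2 (0.32 log units; beyond the scatter). That step placed methyl where fluoro had been on a saturated chain carbon bound to a saturated ring carbon.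

Compound 3 `C[C@H]1C[C@@H](c2ccncc2NC(=O)c2nc(-c3ncccc3F)ccc2N)C[C@@H](O)[C@]1(C)O` changes the same place: hydrogen in place of methyl on a saturated chain carbon bound to a saturated ring carbon. This puts hydrogen in place of methyl, turning ethyl into methyl. Among the compounds with values here, no measured step covers this exact exchange, so a 2.1-fold higher number from compound 1 to compound 2 (0.32 log units; beyond the scatter) is only a rough guide to its size. A small fall, probably within the scatter, is expected. The estimated change is a 1.4-fold lower number from compound 2 to compound 3 (0.14 log units; within the scatter). For compound 3 the expected value is 22 10^-6 cm/s, with an estimated range of 11 10^-6 cm/s to 40 10^-6 cm/s.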

Compound 3, apparent permeability: 6.6 10^-6 cm/s
Compound 3: the middle estimate sits 3.3-fold (0.52 log units) above what was measured, outside the stated range (below it).
By their numbers in this assay, from the lowest: compound 3; then compound 1; then compound 2.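

In this assay, hydrogen on this saturated chain carbon bound to a saturated ring carbon gives the lowest number of the three, so turning ethyl into methyl is no minor trim: the change brings a 4.6-fold lower number from compound 2 to compound 3 (0.66 log units; beyond the scatter), and swapping fluoro for hydrogen brings a 2.2-fold lower number from compound 1 to compound 3 (0.34 log units; beyond the scatter). With these steps, all three groups at this place are separated beyond the scatter, in the order hydrogen, then fluoro, then methyl, and neither of the other two groups matches the methyl in compound 2. Nothing shown here gives a reason for this order.

From the compounds shown here alone, it remains open whether a longer chain, such as propyl, would extend this order beyond compound 2. How an amine or a hydroxyl at this place would compare with these three groups is also left open.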